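The source may hold more compounds than are shown below. What is called first, only, known or untested is meant among the compounds shown, and "the series" means these compounds.

In an ADME assay on HCT-116 cells (Homo sapiens) for cytotoxicity, read by CellTiter-Glo, with a stated time of 72 h (a lower number here means a stronger inhibitor, a higher number a weaker inhibitor), compound 2 `CC1CCN(C2CCN(S(=O)(=O)c3cccc(-c4ccc(F)cc4)c3)CC2)CC1` gives > 5000 nM, which is a limit of the assay rather than a measured number. Compound 1 `CC1CCN(C2CCN(S(=O)(=O)c3cccc(-c4ccccc4C(F)(F)F)c3)CC2)CC1` gives > 5000 nM, also a limit. Compound 3 `COc1cc(C)ccc1S(=O)(=O)N1CCC(N2CCC(C)CC2)CC1` gives > 5000 nM, likewise a limit. The step that the two limits leave unreadable from compound 1 to compound 2 cannot be sized because of the limit of > 5000 nM in this assay, at which 3 of the 3 values shown sit. Compound 4 `COc1ccc(-c2cccc(S(=O)(=O)N3CCC(N4CCC(C)CC4)CC3)c2)cc1` differs from compound 2 by methoxy in place of fluoro on an aromatic carbon. For the measured compounds named here, no measured step speaks to this change, and every value so far is only a limit, so there is nothing to point to a shift in either direction. The expected step is a step that the limit leaves unreadable from compound 2 to compound 4, nothing beyond the scatter. Compound 4 is therefore estimated at 8000 nM, between 3000 nM and 30000 nM, and most likely reported once more only as a limit.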

Compound 4, half-maximal inhibitory concentration: > 5000 nM
Compound 4: a limit, no number; the forecaster's own chance of this, stated with the estimate: 85%; the middle value does not contradict the limit.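

The steps among compound 1, compound 2 and compound 4 cannot be read, because each compound gives only a limit and no number: the limit of > 5000 nM in this assay, at which 4 of the 4 values shown sit.

The compounds shown leave open which change to the shared core, if any, would give a true number in this assay.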